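Hydroxyphenyl position and the step to compound 4

The compounds below may be only part of what the source reports. "The series", "measured", "known", "first", "only" and "open" are said of these compounds alone.

Of the compounds shown here, three have been tested in an assay on isolated protein for inhibition of DNA topoisomerase 1 (Homo sapiens), with a stated time of 30 min, tested at 20 uM; a higher number here means a stronger effect of the compound at the concentration tested, a lower number a weaker effect. Compound 1 `Oc1ccc(-c2cc(-c3ccoc3)cc(-c3ccccc3O)n2)cc1` gives 3.9%. Compound 2 `Oc1ccccc1-c1cc(-c2cccnc2)cc(-c2ccccc2O)n1` gives 0%, and compound 3 `Oc1cccc(-c2cc(-c3cccnc3)cc(-c3ccccc3O)n2)c1` gives 0%. Compound 3 therefore stands level with compound 2, and its distance to compound 1 lies within the scatter, so none of the three is separated from the others. Within the data shown here, the single measured step, no change at the digits printed from compound 2 to compound 3 (within the scatter), is the only precedent for shifting the hydroxyl within this ring, and it produced nothing beyond the scatter. Compound 4 `Oc1ccc(-c2cc(-c3cccnc3)cc(-c3ccccc3O)n2)cc1` differs from compound 3 by 4-hydroxyphenyl in place of 3-hydroxyphenyl on an aromatic carbon. Compound 1 also carries a 4-hydroxyphenyl and gives 3.9%, so no movement beyond the scatter is expected in this assay. Compound 4 is thus expected at 2%, between 0% and 10%, a step of a number 2 percentage points higher from compound 3 to compound 4 (within the scatter) expected to remain within the scatter.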

Compound 4, a percentage reported as inhibition, at one concentration (the size of the read-out at that concentration, not a potency): 0%
The estimate for compound 4 lay 2 percentage points above the measured number, within the range that was stated.
By their numbers in this assay, from the lowest: compounds 2, 3, 4 and 1 (each within the scatter of the next).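

With the pyridin-3-yl group held, the 2-hydroxyphenyl, 3-hydroxyphenyl and 4-hydroxyphenyl groups on this carbon next to the ring nitrogen can now all be compared in this assay: no change at the digits printed from compound 3 to compound 4 (within the scatter), and no change at the digits printed from compound 2 to compound 4 (within the scatter). With the 4-hydroxyphenyl group kept, the second site also gains a direct comparison, pyridin-3-yl in place of furan-3-yl, with a number 3.9 percentage points lower from compound 1 to compound 4 (within the scatter). No independent measurement accompanies these results to help interpret them.

Still open, from the compounds shown here alone, is whether an amine or a carboxylic acid in place of the hydroxyl would move this assay beyond the scatter.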